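Trading the Hydroxy Ester Chain for a Short Ether

The source may hold more compounds than are shown below. What is called first, only, known or untested is meant among the compounds shown, and "the series" means these compounds.

Three esters of one shared core have been tested for cytotoxicity in a functional assay on DU-145 cells (Homo sapiens) for cytotoxicity, read by MTT assay; a higher number here means a weaker inhibitor, a lower number a stronger inhibitor. Compound 1 `CCC(C)(O)CC(=O)O[C@H](CC=C(C)C)C1=CC(=O)c2c(O)ccc(O)c2C1=O` gives 16000 nM. Compound 2 `CCCC(O)CC(=O)O[C@H](CC=C(C)C)C1=CC(=O)c2c(O)ccc(O)c2C1=O` reaches only > 100000 nM, which is a limit of the assay and not a number (the limit of > 100000 nM in this assay, at which 1 of the 3 values shown sits). Compound 3 `CCCC(C)(O)CC(=O)O[C@H](CC=C(C)C)C1=CC(=O)c2c(O)ccc(O)c2C1=O` gives 75000 nM, the higher of the two numbers shown, with compound 1 nearest at a 4.7-fold higher number from compound 1 to compound 3 (0.67 log units; beyond the scatter). Compound 4 `CC(C)=CC[C@@H](OCCO)C1=CC(=O)c2c(O)ccc(O)c2C1=O` has not been measured. Its change from compound 3 is 2-hydroxyethyl in place of (2-hydroxy-2-methylpentyl)carbonyl on an oxygen on a saturated carbon. The measured steps, a 4.7-fold higher number from compound 1 to compound 3 (0.67 log units; beyond the scatter) and an at least 6.2-fold higher number from compound 1 to compound 2 (0.79 log units; beyond the scatter), both alter only the chain that leaves here, and neither tells what removing the whole ester and putting a 2-hydroxyethyl group on that oxygen does. Those steps were modest in size and the core itself is common to all three. Compound 4 is therefore expected to give about 50000 nM, between 10000 nM and 250000 nM. The expected step is a 1.5-fold lower number from compound 3 to compound 4 (0.18 log units; within the scatter), which stays within the scatter.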

Compound 4, half-maximal inhibitory concentration: 9900 nM
The estimate for compound 4 lay 5.1-fold (0.70 log units) above the measured number; the measured number lies below the stated range.
By their numbers in this assay, from the lowest: compounds 4 and 1 (each within the scatter of the next); then compound 3. At a limit, above all of these: compound 2.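

Within the data shown here, putting a 2-hydroxyethyl group on this oxygen in place of the whole ester does not weaken the compound in this assay: there is a 7.6-fold lower number from compound 3 to compound 4 (0.88 log units; beyond the scatter), and a 1.6-fold lower number from compound 1 to compound 4 (0.21 log units; within the scatter), so the ether holds level with the ester that has the lowest number among the earlier compounds. Among these compounds, compound 2 is a limit and not a number, so its step reads only as a floor, an at least 10-fold lower number from compound 2 to compound 4 (1.00 log units; beyond the scatter): the limit of > 100000 nM in this assay, at which 1 of the 4 values shown sits. The earlier steps altered only the ester chain, whereas this one shows that the carbonyl and the larger chain of 9 heavy atoms are not needed to reach this level.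

Going by these compounds, what a plain ethyl ether, a longer hydroxyalkyl chain or an amine on this oxygen would give remains open. On these data alone, whether the ether keeps this level in other cell lines also remains open.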